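The source may report more compounds than this note shows. Statements on the series, on what has been measured and on what is new or still open speak of the compounds shown alone.

Measured in a functional assay on A549 cells (Homo sapiens) for inhibition; a lower number here means a stronger inhibitor, a higher number a weaker inhibitor:

compound 1, `COc1ccc(-c2coc(=O)n2-c2cc(OC)c(OC)c(OC)c2)cc1`, gives 19.9 nM
compound 2, `COc1ccc(-c2coc(=O)n2-c2cc(OC)c(OC)c(OC)c2)cc1O`, gives 3.1 nM
compound 3, `COc1ccc(-c2oc(O)nc2-c2cc(OC)c(OC)c(OC)c2)cc1`, gives 16.9 nM

Compound 1 and compound 2 share a core and differ in one place: hydroxy in place of hydrogen on an aromatic carbon. That change brought a 6.4-fold lower number from compound 1 to compound 2 (0.81 log units; beyond the scatter), a step beyond the scatter of the measurement.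

Compound 3 is built from the same atoms as compound 1, joined differently; the difference between the two cores is not broken down here. In this assay compound 3 and compound 1 give numbers that lie within the scatter of each other, so no order between them can be read.

Compound 4, `COc1ccc(-c2oc(O)nc2-c2cc(OC)c(OC)c(OC)c2)cc1O`, has not yet been measured. It differs from compound 3 by hydroxy in place of hydrogen on an aromatic carbon. The place is described in the same words as for the step from compound 1 to compound 2, so this is the same change made on the core of compound 3.

Because the earlier instance gave a 6.4-fold lower number from compound 1 to compound 2 (0.81 log units; beyond the scatter), a step of similar size is expected here: a 5.6-fold lower number from compound 3 to compound 4 (0.75 log units; beyond the scatter). On that basis compound 4 is estimated at 3 nM, with a plausible range from 1.2 nM to 8 nM, the width allowing for the two cores being different.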

Compound 4, half-maximal inhibitory concentration: 7.9 nM
For compound 4 the middle estimate is 2.6-fold (0.42 log units) below the measured one; the measured number falls inside the stated range.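

In this assay, the change from 4-methoxyphenyl to 3-hydroxy-4-methoxyphenyl also lowered the number on the core of compound 3, with a 2.1-fold lower number from compound 3 to compound 4 (0.33 log units; beyond the scatter), so the direction of the step held on both cores shown. The size of the step did not carry over from one core to the other: the same change on two cores in this assay, a 6.4-fold lower number (0.81 log units; beyond the scatter) from compound 1 to compound 2 and a 2.1-fold lower number (0.33 log units; beyond the scatter) from compound 3 to compound 4, 3.0-fold (0.48 log units) apart, beyond the scatter of two such steps. This shows that the core matters to how much the hydroxy group gives in this series, but it does not show what in the two cores produces the gap, and two cores cannot tell how the change would behave on a third.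

The compounds shown leave open whether an amine or a fluorine on that same aromatic carbon would lower the number as hydroxy does, and whether any such step would again depend on the core. Also open, from the compounds shown here alone, is whether the step would survive if an ethoxy group replaced the methoxy group on that ring.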